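Working notes: configuration changes across the series

The source may report more compounds than this note shows. Statements on the series, on what has been measured and on what is new or still open speak of the compounds shown alone.

Values in an ADME assay on Akata cells (Homo sapiens) for cytotoxicity; on this read-out lower numbers stand for higher toxicity in this test and higher numbers for lower toxicity in this test:
- compound 1 `Nc1ncnc2c1ncn2/C=C1\C[C@@H]1[C@H](O)CO` gives 57000 nM
- compound 2 `Nc1ncnc2c1ncn2/C=C1/C[C@@H]1[C@H](O)CO` gives 50500 nM
- compound 3 `Nc1ncnc2c1ncn2/C=C1\C[C@@H]1[C@@H](O)CO` gives 50600 nM

Compound 3 stands level with the other two. Both steps to it, a 1.1-fold lower number from compound 1 to compound 3 (0.05 log units; within the scatter) and a 1.0-fold higher number from compound 2 to compound 3 (0.00 log units; within the scatter), lie within the scatter.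

Next is compound 4 `Nc1ncnc2c1ncn2/C=C1/C[C@H]1[C@@H](O)CO`: the two compounds have the same atoms and bonds and differ only in configuration as drawn: 2 of 3 stereo elements differ; a stereocentre at a saturated ring carbon is drawn S in compound 3 and R in compound 4; a double bond is drawn E in compound 3 and Z in compound 4.

The double-bond change alone appears in a 1.1-fold lower number from compound 1 to compound 2 (0.05 log units; within the scatter), also within the scatter. Among the measured compounds shown here, no measured step alters the ring stereocentre, so that part of the change is untested. No step beyond the scatter is expected in this assay. The expected step is a 1.0-fold higher number from compound 3 to compound 4 (0.01 log units; within the scatter).

For compound 4 the estimated value is 52000 nM, with an expected range of 25000 nM to 100000 nM.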

Compound 4, half-maximal cytotoxic concentration: 61500 nM
The estimate for compound 4 lay 1.2-fold (0.07 log units) below the measured number; measured number inside the range.
By their numbers in this assay, from the lowest: compounds 2, 3, 1 and 4 (each within the scatter of the next).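

Among the compounds shown here, compound 4 is the first to carry the ring stereocentre drawn R, and in this assay every step to it stays within the scatter: a 1.2-fold higher number from compound 3 to compound 4 (0.08 log units; within the scatter), a 1.2-fold higher number from compound 2 to compound 4 (0.09 log units; within the scatter) and a 1.1-fold higher number from compound 1 to compound 4 (0.03 log units; within the scatter). Each of these steps changes at least two stereo elements, so the ring stereocentre is not read alone, but all four compounds now stand level.

From the compounds shown here alone, the effect of the ring stereocentre with the other two stereo elements held fixed remains open. Also open, going by these compounds, is whether an amine or a carboxylic acid in place of a chain hydroxyl group would give a step beyond the scatter.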